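This account rests on a few compounds, and the source may have more. Where it says the series, first, only, none or still open, it means among the compounds named here.

Measured so far:
- compound 1, `COc1ccccc1/C=c1/[nH]c(=O)/c(=C\c2ccccc2OC)n(C)c1=O`: in a functional assay on K562 cells (Homo sapiens) for cytotoxicity, read by CCK-8 assay, with a stated time of 72 h (on this read-out higher numbers stand for weaker inhibition and lower numbers for stronger inhibition), compound 1 gives 2200 nM
- compound 2, `C=CCn1c(=O)/c(=C\c2ccccc2Cl)[nH]c(=O)/c1=C\c1ccccc1OC`: in this assay compound 2 gives 2500 nM
- compound 3, `C=CCn1c(=O)/c(=C\c2cccc(Br)c2)[nH]c(=O)/c1=C\c1cccc(Br)c1`: in this assay compound 3 is reported as "not active" (no number reported)

Compound 2 holds the higher of the two numbers given, but its gap to compound 1 lies within the scatter of the method, so the two cannot be told apart. Compound 3 has no number at all.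

The next compound, compound 4, `C=CCn1c(=O)/c(=C\c2cc(F)ccc2C)[nH]c(=O)/c1=C\c1ccccc1OC`, keeps the shared core and the allyl group of compound 2 and changes one arm: 5-fluoro-2-methylphenyl in place of 2-chlorophenyl on a double-bonded chain carbon bound to an aromatic carbon. For the measured compounds named here, no pair of compounds differing in only one place has yet been measured, so there is no single-change step to lean on. The only other entry, compound 3, changes both arms at once and is not active, which cannot be traced to either arm alone.

With so little to go on, the step from compound 2 to compound 4 is expected to be small, perhaps toward a slightly weaker result, and likely no further than the scatter allows: a 1.2-fold higher number from compound 2 to compound 4 (0.08 log units; within the scatter). For compound 4 in this assay the estimate is 3000 nM, with a range from 1200 nM to 8000 nM.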

Compound 4, half-maximal inhibitory concentration: 1800 nM
Compound 4: middle estimate off by 1.7-fold (0.22 log units), on the high side; the measured number falls inside the stated range.
By their numbers in this assay, from the lowest: compounds 4, 1 and 2 (each within the scatter of the next).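

In this assay, for the compounds shown here, placing 5-fluoro-2-methylphenyl in place of 2-chlorophenyl on a double-bonded chain carbon bound to an aromatic carbon gives a 1.4-fold lower number from compound 2 to compound 4 (0.14 log units; within the scatter) and so provides the first comparison in which only one place differs. The two compounds cannot be told apart, even though the arm loses its chlorine and gains both a fluorine and a methyl group. At this position, then, one substituted phenyl can stand in for another with no change in the cell result that the method can detect, at least for this pair.

The compounds shown leave open whether this arm can move away from a substituted phenyl, for example to a phenyl carrying an amine or a carboxylic acid, and whether any such group would shift the result beyond the scatter. Also open are the effect of a longer chain in place of the allyl group and which arm of compound 3 lies behind its "not active" report.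

No supporting information accompanies these results, so this step remains an observation without an explanation.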